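Rearranged bicycle on the lactam side chain: compound 3

The source may report more compounds than this note shows. Statements on the series, on what has been measured and on what is new or still open speak of the compounds shown alone.

Compound 2 `O=C1[C@@H](NS(=O)(=O)c2ccc(-c3ccncc3)s2)CCN1Cc1cc2c[nH]ccc-2n1` gives 21% in an assay on isolated protein for inhibition of coagulation factor X (Oryctolagus cuniculus), tested at 1 uM; a lower number here means less inhibition, a higher number more inhibition at the concentration tested (going by the name of the read-out). Compound 1 `O=C1[C@@H](NS(=O)(=O)c2ccc(-c3ccccn3)s2)CCN1Cc1cc2c[nH]ccc-2n1` gives 11% in this assay, and the step of a number 10 percentage points higher from compound 1 to compound 2 (within the scatter) lies within the scatter, so these two numbers cannot be told apart. Compound 3 `O=C1[C@@H](NS(=O)(=O)c2ccc(-c3ccncc3)s2)CCN1Cc1cc2cc[nH]cc-2n1` differs from compound 2 by a group of 9 heavy atoms (7 carbon, 2 nitrogen; one five-membered aromatic ring with 1 hetero atom, one six-membered aromatic ring with 1 hetero atom) in place of a group of 9 heavy atoms (7 carbon, 2 nitrogen; one five-membered aromatic ring with 1 hetero atom, one six-membered aromatic ring with 1 hetero atom), on a saturated chain carbon bound to an amide-type nitrogen in a ring. Within the data shown here, no measured step bears on this change; the one step on record, a number 10 percentage points higher from compound 1 to compound 2 (within the scatter), concerns pyridin-4-yl in place of pyridin-2-yl and was within the scatter. For compound 3 the estimate is 20% (range 7% to 35%), meaning an expected step of a number 1 percentage points lower from compound 2 to compound 3 (within the scatter), none beyond the scatter.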

Compound 3, a percentage reported as inhibition, at one concentration (the size of the read-out at that concentration, not a potency): 50%
The estimate for compound 3 lay 30 percentage points below the measured number; measured number above the stated range.
By their numbers in this assay, from the lowest: compounds 1 and 2 (each within the scatter of the next); then compound 3.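

In this assay the place on a saturated chain carbon bound to an amide-type nitrogen in a ring responds to atoms merely joined differently: the number is a number 29 percentage points higher from compound 2 to compound 3 (beyond the scatter), with atom counts unchanged. Among these compounds, this is the first step beyond the scatter, whereas the pyridinyl change was not. Nothing on record accounts for the rise. Open, going by these compounds, is whether an amine or a carboxylic acid on the group entering in compound 3 would shift the number further, and whether pyridin-2-yl would behave as pyridin-4-yl does there.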